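Swapping Chlorophenyl for Hydroxyphenyl on a Shared Core

The compounds below may be only part of what the source reports. "The series", "measured", "known", "first", "only" and "open" are said of these compounds alone.

Measured so far:
compound 1 `CC(C)c1ccc(-c2nc(SCc3cn(CC(=O)NC(=O)Nc4ccccn4)nn3)nc(Nc3ccc(Cl)cc3)c2C#N)cc1`, giving 860 nM
compound 2 `CC(C)c1ccc(-c2nc(SCc3cn(CC(=O)NC(=O)Nc4ccccn4)nn3)nc(Nc3cccc(Cl)c3)c2C#N)cc1`, giving 1130 nM

In a functional assay on B16-F10 cells (Mus musculus) for inhibition, read by MTT assay, with a stated time of 72 h (on this read-out higher numbers stand for weaker inhibition and lower numbers for stronger inhibition), compound 1 gives 860 nM and compound 2 gives 1130 nM. For the measured compounds named here, compound 1 stands beside compound 2, its only measured neighbour, the two separated by a 1.3-fold higher number from compound 1 to compound 2 (0.12 log units; within the scatter). Compound 3 `CC(C)c1ccc(-c2nc(SCc3cn(CC(=O)NC(=O)Nc4ccccn4)nn3)nc(Nc3ccccc3O)c2C#N)cc1` is not yet measured. It differs from compound 1 by 2-hydroxyphenyl in place of 4-chlorophenyl on a nitrogen on an aromatic ring. Going by the values given here, the single measured step exchanges 4-chlorophenyl for 3-chlorophenyl and stays within the scatter; no measured step exchanges a chlorophenyl for a hydroxyphenyl, so nothing here anchors the size of this change. Compound 3 is therefore expected to give about 1200 nM, within 400 nM to 4000 nM, an expected step of a 1.4-fold higher number from compound 1 to compound 3 (0.14 log units; within the scatter).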

Compound 3, half-maximal inhibitory concentration: 16100 nM
The estimate for compound 3 lay 13-fold (1.13 log units) below the measured number; measured number outside the range, above it.
By their numbers in this assay, from the lowest: compounds 1 and 2 (each within the scatter of the next); then compound 3.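

On this nitrogen, the aryl group is less interchangeable than the two chlorophenyl compounds suggested. In this assay, 2-hydroxyphenyl in place of 4-chlorophenyl gives a 19-fold higher number from compound 1 to compound 3 (1.27 log units; beyond the scatter) and in place of 3-chlorophenyl gives a 14-fold higher number from compound 2 to compound 3 (1.15 log units; beyond the scatter) on the same core, so this exchange weakens inhibition far more than moving the chlorine did. No evidence is available on why this happens. As far as these compounds go, whether a methoxyphenyl or an aminophenyl group on this nitrogen would stay close to compound 1 or weaken inhibition as in compound 3 remains open.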